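Methoxy in place of hydrogen: compound 3 to compound 4

A few compounds are considered here, and "the series" means these few. Any claim that something is new, unique, unknown or untested is made for them only; others in the source may bear on it.

Measured in a functional assay on AGS cells (Homo sapiens) for antiproliferative activity, read by MTT assay, with a stated time of 48 h; a lower number here means a stronger inhibitor of growth, a higher number a weaker inhibitor of growth:
- compound 1 `COc1ccc(N(C)c2ncnc3c2ncn3Cc2cc(OC)c(OC)c(OC)c2)cc1`: > 100000 nM (a limit, not a number)
- compound 2 `COc1ccc(N(C)c2nc(Cl)nc3c2ncn3Cc2ccc(OC)c(OC)c2)cc1`: 56000 nM
- compound 3 `COc1ccc(N(C)c2nc(Cl)nc3c2ncn3Cc2cc(OC)cc(OC)c2)cc1`: 69000 nM

Compound 1 gives only a limit in this assay. That leaves two numbers, and compound 3, at 69000 nM, is the higher of them only nominally, as it lies within the scatter of compound 2, at 56000 nM.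

Compound 4 `COc1ccc(N(C)c2nc(Cl)nc3c2ncn3Cc2cc(OC)c(OC)c(OC)c2)cc1` has not yet been measured. It carries methoxy in place of hydrogen on an aromatic carbon, ortho to two methoxy groups and para to a large group (methoxy in place of hydrogen on an aromatic carbon).

Among the measured compounds shown here, one measured step bears on this change: a 1.2-fold higher number from compound 2 to compound 3 (0.09 log units; within the scatter). That step swaps 3,4-dimethoxyphenyl for 3,5-dimethoxyphenyl and adds no group, so the support is indirect. No step beyond the scatter is therefore expected in this assay, and no direction is favoured. The expected change is a 1.2-fold lower number from compound 3 to compound 4 (0.06 log units; within the scatter). Compound 4 is estimated at 60000 nM, with an expected range of 20000 nM to 120000 nM.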

Compound 4, concentration for 50% growth inhibition: 85000 nM
The estimate for compound 4 lay 1.4-fold (0.15 log units) below the measured number; the range from low to high includes it.
By their numbers in this assay, from the lowest: compounds 2, 3 and 4 (each within the scatter of the next). At a limit, above all of these: compound 1.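

In this assay, methoxy in place of hydrogen on the aromatic carbon ortho to two methoxy groups and para to a large group gives a 1.2-fold higher number from compound 3 to compound 4 (0.09 log units; within the scatter) here, and the same exchange starting from the 3,4-dimethoxyphenyl compound gives a 1.5-fold higher number from compound 2 to compound 4 (0.18 log units; within the scatter) as well. Neither step leaves the scatter, so a third methoxy on this ring brings no readable change in these compounds. Chloro in place of hydrogen on the core gives an at least 1.1-fold lower number from compound 1 to compound 4 (0.07 log units; that floor lies within the scatter) only as a floor, since the value of compound 1 is a limit and not a number: the limit of > 100000 nM in this assay, at which 1 of the 4 values shown sits.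

From the compounds shown here alone, whether a hydroxy group, an amine or a longer alkoxy chain at this ring position would give a step beyond the scatter stays open. Going by these compounds, the size of the chloro step also stays open, with no number on the side of compound 1.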